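Chalcone-type series: heteroaryl ketone variation at the carbonyl

The source may report more compounds than this note shows. Statements on the series, on what has been measured and on what is new or still open speak of the compounds shown alone.

Measured compounds in a functional assay on MCF7 cells (Homo sapiens) for antiproliferative activity, read by XTT assay, with a stated time of 72 h; a lower number here means a stronger inhibitor, a higher number a weaker inhibitor:
compound 1 `COc1ccc(-c2cc3ccccc3nc2/C=C/C(=O)c2ccc(O)cc2)cc1` gives 6710 nM
compound 2 `COc1ccc(-c2cc3ccccc3nc2/C=C/C(=O)c2ccc([N+](=O)[O-])cc2)cc1` gives 4110 nM
compound 3 `COc1ccc(-c2cc3ccccc3nc2/C=C/C(=O)c2ccccn2)cc1` gives 810 nM

Compound 3 gives the lowest number of the measured set. The step of an 8.3-fold lower number from compound 1 to compound 3 (0.92 log units; beyond the scatter) and the step of a 5.1-fold lower number from compound 2 to compound 3 (0.71 log units; beyond the scatter) both lie beyond the scatter, so compound 3 is the strongest inhibitor among the three. The step of a 1.6-fold lower number from compound 1 to compound 2 (0.21 log units; within the scatter) lies within the scatter.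

Compound 4 `COc1ccc(-c2cc3ccccc3nc2/C=C/C(=O)c2cnc(N)nc2C)cc1` differs from compound 3 as follows: 2-amino-4-methylpyrimidin-5-yl in place of pyridin-2-yl on a carbonyl carbon. Going by the values given here, no measured pair exchanges one heteroaryl ring for another at this position; the measured steps only show that the pyridin-2-yl ketone of compound 3 gives a lower number than the 4-hydroxyphenyl ketone of compound 1 and the 4-nitrophenyl ketone of compound 2. The change to compound 4 is larger than either of those in atoms and in donors and acceptors, so the expectation is weak. Compound 4 is expected to sit near compound 3 or somewhat higher, the estimated step being a 2.2-fold higher number from compound 3 to compound 4 (0.35 log units; beyond the scatter). The estimate for compound 4 is 1800 nM with a range from 450 nM to 7200 nM.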

Compound 4, half-maximal inhibitory concentration: > 10000 nM
Compound 4 was reported as a limit; the forecaster's own chance of this, stated with the estimate: 5%; middle value at least 5.5-fold (0.74 log units) away from the limit.
By their numbers in this assay, from the lowest: compound 3; then compounds 2 and 1 (each within the scatter of the next). At a limit, above all of these: compound 4.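

In this assay, compound 4 is reported only as a limit of the assay: the limit of > 10000 nM in this assay, at which 1 of the 4 values shown sits. A heteroaryl ketone alone therefore does not secure a low number at this carbonyl carbon: 2-amino-4-methylpyrimidin-5-yl in place of pyridin-2-yl gives an at least 12-fold higher number from compound 3 to compound 4 (1.09 log units; beyond the scatter). The same group also separates from the 4-nitrophenyl ketone, with an at least 2.4-fold higher number from compound 2 to compound 4 (0.38 log units; beyond the scatter), whereas an at least 1.4-fold higher number from compound 1 to compound 4 (0.17 log units; that floor lies within the scatter) has a floor within the scatter and so sets no order against the 4-hydroxyphenyl ketone.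

The entering group differs from pyridin-2-yl in its amino group, its methyl group and its ring nitrogens all at once, and the compounds shown do not separate these changes. Also open, as far as these compounds go, is how an unsubstituted pyrimidin-5-yl or a pyridin-3-yl ketone would read at this carbonyl carbon.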